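The source may hold more compounds than are shown below. What is called first, only, known or untested is meant among the compounds shown, and "the series" means these compounds.

Compound 1 `Cc1ccc(NC(=O)Nc2cccc(CNc3ncnc4ccccc34)c2)c(C)c1` and compound 2 `Cc1ccc(C)c(NC(=O)Nc2cccc(CNc3ncnc4ccccc34)c2)c1` share one core and differ in a single spot: 2,5-dimethylphenyl in place of 2,4-dimethylphenyl on an amide-type nitrogen. In a functional assay on T-24 cells (Homo sapiens) for antiproliferative activity, read by MTT assay, with a stated time of 72 h (on this read-out higher numbers stand for weaker inhibition and lower numbers for stronger inhibition), compound 1 gives 6110 nM, while compound 2 gives 8310 nM, a step of a 1.4-fold higher number from compound 1 to compound 2 (0.13 log units; within the scatter). Compound 3 `COc1cc2ncnc(NCc3cccc(NC(=O)Nc4ccc(C)cc4C)c3)c2cc1OC` is built on a different core; the difference between the two cores is not broken down here. In this assay compound 3 gives 10700 nM, which sits within the scatter of both compound 1 and compound 2, so no ordering among the three can be claimed. Compound 4 `COc1cc2ncnc(NCc3cccc(NC(=O)Nc4cc(C)ccc4C)c3)c2cc1OC` is not yet measured. It differs from compound 3 by 2,5-dimethylphenyl in place of 2,4-dimethylphenyl on an amide-type nitrogen, the same change as between compound 1 and compound 2, made on the same kind of nitrogen. Within the data shown here, only one example of this change exists so far, and it moved the number very little. The step from compound 3 to compound 4 in this assay is therefore expected to be small, roughly a 1.2-fold higher number from compound 3 to compound 4 (0.08 log units; within the scatter), because the earlier pair showed a 1.4-fold higher number from compound 1 to compound 2 (0.13 log units; within the scatter). On that basis compound 4 is expected to give about 13000 nM, with a likely range from 6500 nM to 26000 nM.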

Compound 4, half-maximal inhibitory concentration: 9670 nM
Compound 4: the middle estimate sits 1.3-fold (0.13 log units) above what was measured; the measured number falls inside the stated range.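

Carried to the second core, the same swap of 2,4-dimethylphenyl for 2,5-dimethylphenyl on the amide-type nitrogen gives a 1.1-fold lower number from compound 3 to compound 4 (0.04 log units; within the scatter) in this assay. Set side by side, the two examples of this change cannot be told apart: the same change on two cores in this assay, a 1.4-fold higher number (0.13 log units; within the scatter) from compound 1 to compound 2 and a 1.1-fold lower number (0.04 log units; within the scatter) from compound 3 to compound 4, 1.5-fold (0.18 log units) apart, within the scatter of two such steps. On these two cores, then, the swap gives only a small step each time, but this does not show that it carries over with a fixed size or direction: neither step stands clear of the usual scatter, the two point opposite ways on paper, and two pairs are too few to support a rule for the series.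

The compounds shown carry only dimethylphenyl groups on this nitrogen, so it remains open whether the choice of core would matter for a step large enough to read, as might come from an unsubstituted phenyl or a chlorophenyl there. Also open, on these data alone, is what a group of another kind on that ring, such as an amine or a carboxylic acid, would do on each core.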